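This account rests on a few compounds, and the source may have more. Where it says the series, first, only, none or still open, it means among the compounds named here.

Compounds in hand, with a functional assay on QGY7701 cells (Homo sapiens) for cytotoxicity, read by MTT assay, with a stated time of 24 h (on this read-out higher numbers stand for weaker inhibition and lower numbers for stronger inhibition), as the read-out throughout:
compound 1 `C=CC1=C(C(=O)Nc2ccccc2)C(c2ccc(Cl)c(Cl)c2)OC1`, > 100000 nM
compound 2 `C=CC1=C(C(=O)Nc2ccccc2OC)C(c2ccc(F)cc2)OC1`, 52800 nM
compound 3 `C=CC1=C(C(=O)NCCC)C(c2ccc(OC)c(OC)c2)OC1`, > 100000 nM

The value of compound 1 is a limit of the assay, not a number. The value of compound 3 is likewise a limit. Compound 2 alone gives a number, while the others sit at the limit of > 100000 nM in this assay, at which 2 of the 3 values shown sit. Compound 1 therefore stands at the weak end of what is shown, and no measured step reaches it. Compound 4 `C=CC1=C(C(=O)NCCC)C(c2ccc(Cl)c(Cl)c2)OC1` differs from compound 1 by propyl in place of phenyl on an amide-type nitrogen. Going by the values given here, no measured pair isolates this change; compound 3, which carries the propylamino amide, also sits at the limit. The step of a number no higher from compound 1 to compound 4 (the limit leaves the size open) is expected to be none beyond the scatter. Compound 4 is accordingly estimated at 100000 nM, between 40000 nM and 300000 nM, most likely reported again only as a limit.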

Compound 4, half-maximal inhibitory concentration: 31300 nM
Estimate against measurement, compound 4: 3.2-fold (0.50 log units) above, and the stated range ends above it.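

In this assay, propyl in place of phenyl on an amide-type nitrogen gives an at least 3.1-fold lower number from compound 1 to compound 4 (0.50 log units; beyond the scatter), the only readable step at this position among the compounds shown. Going by these compounds, the value of compound 1 is a limit, so the full size of this step stays open: the limit of > 100000 nM in this assay, at which 2 of the 4 values shown sit. The propylamino amide does not give a number in every compound: compound 3 also carries it, and its > 100000 nM is a limit.

Open, on these data alone, is how a longer chain, such as butyl, or a chain ending in an amine would read at this nitrogen.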